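The source may hold more compounds than are shown below. What is called first, only, known or untested is meant among the compounds shown, and "the series" means these compounds.

Compound 1 `COc1ccccc1/C=C1\CCc2cc(OC)c(OC)cc2C1=O` carries a 2-methoxyphenyl on the double-bonded chain carbon of the shared core. In a functional assay on Jurkat cells (Homo sapiens) for antiproliferative activity, read by MTT assay (on this read-out lower numbers stand for stronger inhibition and higher numbers for weaker inhibition), compound 1 returns only a limit, > 50000 nM, not a number. Compound 2 `COc1cc2c(cc1OC)C(=O)/C(=C/c1ccc(O)c(C(=O)O)c1)CC2` in this assay likewise returns only a limit, > 50000 nM. Among the measured compounds shown here, compound 3 `COc1cc(/C=C2\CCc3cc(OC)c(OC)cc3C2=O)cc(OC)c1` is the one member with a number in this assay, giving 5000 nM. Compound 1 thus sits at the limit of > 50000 nM in this assay, at which 2 of the 3 values shown sit, with no gap to a neighbour measurable.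

Compound 4 `COc1cc2c(cc1OC)C(=O)/C(=C/c1cc(Cl)cc(Cl)c1)CC2` differs from compound 1 by 3,5-dichlorophenyl in place of 2-methoxyphenyl on a double-bonded chain carbon bound to a double-bonded ring carbon. For the measured compounds named here, no measured step exists for this pair. Compound 4 is expected to move toward a measurable number, a step of an at least 6.2-fold lower number from compound 1 to compound 4 (0.79 log units; beyond the scatter), because compound 3 gives 5000 nM in this assay. Compound 4 is estimated at 8000 nM, between 2000 nM and 50000 nM.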

Compound 4, half-maximal inhibitory concentration: 7000 nM
The estimate for compound 4 lay 1.1-fold (0.06 log units) above the measured number; the range from low to high includes it.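

In this assay, among the compounds shown here, the change to 3,5-dichlorophenyl on a double-bonded chain carbon bound to a double-bonded ring carbon gives the only readable step: an at least 7.1-fold lower number from compound 1 to compound 4 (0.85 log units; beyond the scatter). A measurable number at this position does not need a hydrogen-bond acceptor on the entering group, as 3,5-dichlorophenyl has none. The step remains open-ended, with compound 1 reading only as a limit: the limit of > 50000 nM in this assay, at which 2 of the 4 values shown sit.

Still open, on these data alone, is whether the chlorine atoms or their placement matter more, as both differ between the two groups. As far as these compounds go, how an amine or a nitrile on this phenyl ring would read also remains open.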